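The source may hold more compounds than are shown below. What is called first, only, known or untested is meant among the compounds shown, and "the series" means these compounds.

Compound 1 `CCN(CC)c1ccc2cc(C(=O)c3ccc(N4CCN(C(=O)CN5CCN(S(=O)(=O)C6CC6)CC5)CC4)cc3)oc2c1`: 17300 nM in a functional assay on A549 cells (Homo sapiens) for cytotoxicity, read by MTT assay, with a stated time of 48 h; a higher number here means a weaker inhibitor, a lower number a stronger inhibitor.
Compound 2 `CCN(CC)c1ccc2cc(C(=O)c3ccc(N4CCN(C(=O)CN5CCN(S(=O)(=O)c6ccc(OC(F)(F)F)cc6)CC5)CC4)cc3)oc2c1`: > 40000 nM in this assay, a limit of the assay and not a number.

Compound 2 sits at the upper limit of this assay. Going by the values given here, the only measured step, an at least 2.3-fold higher number from compound 1 to compound 2 (0.36 log units; beyond the scatter), ends at that limit (the limit of > 40000 nM in this assay, at which 1 of the 2 values shown sits). Compound 3 `CCN(CC)c1ccc2cc(C(=O)c3ccc(N4CCN(C(=O)CN5CCN(S(=O)(=O)c6ccc(C(F)(F)F)cc6)CC5)CC4)cc3)oc2c1` carries the change (trifluoromethyl in place of trifluoromethoxy on an aromatic carbon). Among the compounds with values here, no measured step concerns this exchange, so no step beyond the scatter is expected in this assay. Compound 3 is estimated at 45000 nM (range 15000 nM to 150000 nM). This estimate means an expected step that the limit leaves unreadable from compound 2 to compound 3, most likely again reported only as a limit.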

Compound 3, half-maximal inhibitory concentration: > 40000 nM
Compound 3 gave a limit, no number; the forecaster's own chance of this, stated with the estimate: 70%; the middle value lies beyond the limit too.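

In this assay compound 3 gives > 40000 nM, a limit of the assay and not a number. On the sulfonyl sulfur, 4-(trifluoromethyl)phenyl in place of cyclopropyl gives an at least 2.3-fold higher number from compound 1 to compound 3 (0.36 log units; beyond the scatter), so a second aryl group now shares the direction seen with 4-(trifluoromethoxy)phenyl. The exchange of trifluoromethoxy for trifluoromethyl cannot be read as a step: the limit of > 40000 nM in this assay, at which 2 of the 3 values shown sit.

From the compounds shown here alone, how far compound 2 and compound 3 lie apart stays open. Also open, going by these compounds, is whether an amine or a carboxylic acid in place of trifluoromethyl would give a number rather than a limit.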